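A few compounds are considered here, and "the series" means these few. Any claim that something is new, unique, unknown or untested is made for them only; others in the source may bear on it.

Measured in a functional assay on THP-1 cells (Homo sapiens) for inhibition, read by ELISA, with stated times of 30 min and 24 h, tested at 10 uM; a lower number here means a weaker effect, a higher number a stronger effect of the compound at the concentration tested:
compound 1 `COc1cc(OC)c(C(=O)c2ccccc2F)c(O)c1CN1CCCC1` gives 87%
compound 2 `COc1cc(OC)c(C(=O)c2cccc(Cl)c2)c(O)c1CN1CCCC1` gives 81%
compound 3 `COc1cc(OC)c(C(=O)c2cccc(F)c2)c(O)c1CN1CCCC1` gives 93%

Compound 1 stands second highest of the three numbers, with a number 6 percentage points lower from compound 1 to compound 2 (within the scatter) and a number 6 percentage points higher from compound 1 to compound 3 (within the scatter) both within the scatter; only a number 12 percentage points higher from compound 2 to compound 3 (beyond the scatter) reaches beyond it, and modestly. Compound 4 `COc1cc(OC)c(C(=O)c2ccccc2F)c(O)c1CN1CCCCC1` carries piperidin-1-yl in place of pyrrolidin-1-yl on a saturated chain carbon bound to an aromatic carbon. Among the measured compounds shown here, all three measured steps exchange the substituted phenyl on a carbonyl carbon; none touches the group on the saturated chain carbon bound to an aromatic carbon, so no measured step bears on this change. With the halogen changes themselves mostly within the scatter, compound 4 is expected to stay close to compound 1: the expected step is a number 2 percentage points lower from compound 1 to compound 4 (within the scatter), no change beyond the scatter. Compound 4 is estimated at 85% in this assay, with a range of 70% to 96%.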

Compound 4, a percentage reported as activity, at one concentration (the size of the read-out at that concentration, not a potency): 84%
The estimate for compound 4 lay 1 percentage points above the measured number; low and high end bracket the measured number.
By their numbers in this assay, from the lowest: compounds 2, 4, 1 and 3 (each within the scatter of the next, the first and the last beyond it).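

The exchange of (pyrrolidin-1-yl)methyl for (piperidin-1-yl)methyl is the first change shown on a saturated chain carbon bound to an aromatic carbon, and in this assay it gives a number 3 percentage points lower from compound 1 to compound 4 (within the scatter) with the 2-fluorophenyl on the carbonyl carbon held fixed. The six-membered ring thus takes the place of the five-membered ring with no change beyond the scatter at this one concentration. Nothing available explains this result.

Open, as far as these compounds go, are a morpholin-4-yl ring or an open-chain diethylamino group at this place. Also open, from the compounds shown here alone, is whether the same step holds with 3-fluorophenyl or 3-chlorophenyl on the carbonyl carbon.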